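Notes on replacing 1-methyl-1H-pyrazol-3-yl with 3-cyanophenyl

The compounds below may be only part of what the source reports. "The series", "measured", "known", "first", "only" and "open" are said of these compounds alone.

Measured in a functional assay on MCF7 cells (Homo sapiens) for antiproliferative activity, read by MTT assay, with a stated time of 72 h; a lower number here means a stronger inhibitor, a higher number a weaker inhibitor:
- compound 1 `C=CC(=O)Nc1cccc(Oc2nc(Nc3ccn(C)n3)nc3c2CSCC3)c1`: > 50000 nM
- compound 2 `CC/C=C/C(=O)Nc1cccc(Oc2nc(Nc3ccn(C)n3)nc3c2CSCC3)c1`: > 50000 nM
- compound 3 `C=C(C)C(=O)Nc1cccc(Oc2nc(Nc3ccn(C)n3)nc3c2CSCC3)c1`: > 50000 nM

Each of these entries is a limit and not a number. Compound 1 stands at > 50000 nM, which is a limit. The whole set ends at the limit of > 50000 nM in this assay, at which 3 of the 3 values shown sit.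

Compound 4 `C=CC(=O)Nc1cccc(Oc2nc(Nc3cccc(C#N)c3)nc3c2CSCC3)c1` keeps the core of compound 1 and differs by 3-cyanophenyl in place of 1-methyl-1H-pyrazol-3-yl on a nitrogen on an aromatic ring. In short, 3-cyanophenyl stands in place of 1-methyl-1H-pyrazol-3-yl on a nitrogen on an aromatic ring.

The measured steps are a step that the two limits leave unreadable from compound 1 to compound 2, a step that the two limits leave unreadable from compound 1 to compound 3 and a step that the two limits leave unreadable from compound 2 to compound 3. All three change the group on the carbonyl carbon, not the group on this nitrogen, and none has a readable size. They therefore give no measure for this change. In this assay only a modest gain in strength is expected, and another limit remains quite possible. The expected change is an at least 1.6-fold lower number from compound 1 to compound 4 (0.22 log units; that floor lies within the scatter). The estimated value for compound 4 is 30000 nM, with an expected range of 6000 nM to 80000 nM.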

Compound 4, half-maximal inhibitory concentration: 21700 nM
Compound 4: middle estimate off by 1.4-fold (0.14 log units), on the high side; measured number inside the range.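

In this assay, 3-cyanophenyl in place of 1-methyl-1H-pyrazol-3-yl on a nitrogen on an aromatic ring gives an at least 2.3-fold lower number from compound 1 to compound 4 (0.36 log units; beyond the scatter), while the steps among compound 1, compound 2 and compound 3 cannot be read. The group on this nitrogen is therefore the first place in the series where a change moves the read-out off the limit of the assay, whereas the changes on the carbonyl carbon give no readable size. Compound 4 is the only compound shown with a number and not a limit: the limit of > 50000 nM in this assay, at which 3 of the 4 values shown sit.

Compound 1 gives > 50000 nM, which is a limit, so the step remains a floor with no known upper end. Also open, from the compounds shown here alone, is whether an amine or a carboxylic acid in place of the nitrile, or 1-methylethenyl on the carbonyl carbon alongside 3-cyanophenyl, would lower the number further.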